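The source may hold more compounds than are shown below. What is called first, only, known or untested is meant among the compounds shown, and "the series" means these compounds.

Measured in a functional assay on K562 cells (Homo sapiens), read by MTT assay, with a stated time of 72 h; a higher number here means a weaker inhibitor, a lower number a stronger inhibitor:
compound 1 `COc1ncnc2c1c(-c1ccoc1)cn2[C@@H]1O[C@H](CO)[C@@H](O)[C@H]1O` gives 190 nM.
compound 2 `C#Cc1cn([C@@H]2O[C@H](CO)[C@@H](O)[C@H]2O)c2ncnc(OC)c12` gives 300 nM.
compound 3 `COc1ncnc2c1c(I)cn2[C@@H]1O[C@H](CO)[C@@H](O)[C@H]1O` is reported only as a limit, > 20000 nM.

Compound 3 thus sits at the limit of > 20000 nM in this assay, at which 1 of the 3 values shown sits, and is the weakest of the three, since both an at least 100-fold higher number from compound 1 to compound 3 (2.02 log units; beyond the scatter) and an at least 66-fold higher number from compound 2 to compound 3 (1.82 log units; beyond the scatter) are large, while a 1.6-fold higher number from compound 1 to compound 2 (0.20 log units; within the scatter) is not. Compound 4 `COc1ncnc2c1c(-c1ccco1)cn2[C@@H]1O[C@H](CO)[C@@H](O)[C@H]1O` differs from compound 3 by furan-2-yl in place of iodo on an aromatic carbon. The two large steps into compound 3 both concern the loss of a carbon substituent for iodo, so the reverse move in compound 4 is expected to give a large step downward in this assay, estimated as an at least 66-fold lower number from compound 3 to compound 4 (1.82 log units; beyond the scatter). Compound 4 is therefore expected near 300 nM, in the range 100 nM to 1500 nM.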

Compound 4, half-maximal inhibitory concentration: 60 nM
Compound 4: the middle estimate sits 5.0-fold (0.70 log units) above what was measured, and the stated range ends above it.
By their numbers in this assay, from the lowest: compound 4; then compounds 1 and 2 (each within the scatter of the next). At a limit, above all of these: compound 3.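

In this assay, the attachment point of the furan matters at this position: furan-2-yl in place of furan-3-yl gives a 3.2-fold lower number from compound 1 to compound 4 (0.50 log units; beyond the scatter). Furan-2-yl in place of ethynyl gives a 5.0-fold lower number from compound 2 to compound 4 (0.70 log units; beyond the scatter), so it separates from ethynyl, whereas furan-3-yl and ethynyl lay within the scatter of each other. Compound 3 is reported only as a limit, so an at least 330-fold lower number from compound 3 to compound 4 (2.52 log units; beyond the scatter) is a bound and not an exact size: the limit of > 20000 nM in this assay, at which 1 of the 4 values shown sits.

On these data alone, it remains open whether the gain from furan-2-yl extends to thiophene or phenyl rings. An amine or a longer chain at this position is also untested in the compounds shown.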